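Trimming a cyclohexyl to methyl: expected metabolic stability

A few compounds are considered here, and "the series" means these few. Any claim that something is new, unique, unknown or untested is made for them only; others in the source may bear on it.

Measured so far:
compound 2 `c1cnc2c(c1)CCC[C@@H]2N(CC1CCCCC1)C[C@H]1Cc2c(cccc2N2CCNCC2)CN1` — 81.6%
compound 3 `CN(C[C@H]1Cc2c(cccc2N2CCN3CCC[C@@H]3C2)CN1)[C@H]1CCCc2cccnc21` — 52.2%
compound 1 `Cc1cnc(CN(C)C[C@H]2Cc3c(cccc3N3CCNCC3)CN2)c(C)c1` — "not determined" (no result reported)

In an ADME assay on microsomes from liver (Homo sapiens) for metabolic stability, read by LC-MS, with a stated time of 10 min (on this read-out higher numbers stand for a more stable compound and lower numbers for a less stable compound), compound 2 gives 81.6%, the higher of the two numbers available. Compound 3 gives 52.2%, a gap to compound 2 that lies beyond the usual scatter. In this assay compound 1 gives "not determined" (no result reported).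

The unmeasured compound 4 `CCN(C[C@H]1Cc2c(cccc2N2CCNCC2)CN1)[C@H]1CCCc2cccnc21` differs from compound 2 in one place: methyl in place of cyclohexyl on a saturated chain carbon bound to an amine nitrogen. Going by the values given here, no pair of measured compounds shows this exact change, so the size of the step must be judged from the shared core alone.

Compound 4 is expected to remain below compound 2, with the step of a number 16.6 percentage points lower from compound 2 to compound 4 (beyond the scatter) estimated to fall beyond the scatter. The estimate for compound 4 is 65%, within 40% to 88%.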

Compound 4, percent of the compound remaining: 79.1%
Beside the measured number, compound 4's estimate is 14.1 percentage points below it, and the stated range covers the measured number.
By their numbers in this assay, from the lowest: compound 3; then compounds 4 and 2 (each within the scatter of the next).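

In this assay, methyl in place of cyclohexyl on a saturated chain carbon bound to an amine nitrogen gives a number 2.5 percentage points lower from compound 2 to compound 4 (within the scatter), so this read-out does not tell the two compounds apart. At this position, the cyclohexyl can thus give way to the much smaller methyl with no step beyond the scatter. No measurement shown here accounts for this result. Still open, on these data alone, is whether an amine, a carboxylic acid or a longer chain at this position would read the same.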